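This account rests on a few compounds, and the source may have more. Where it says the series, first, only, none or still open, it means among the compounds named here.

The series shares one core, carrying a trifluoromethyl-substituted phenyl ring and an amine-linked side chain. Compound 1 `N#Cc1ccc(CNc2nc(-c3ccccc3C(F)(F)F)nc3ccccc23)cc1` gives 5700 nM in an assay on a protein complex for inhibition of ubiquitin carboxyl-terminal hydrolase 1/WD repeat-containing protein 48 (Homo sapiens), read by fluorescence; on this read-out higher numbers stand for weaker inhibition and lower numbers for stronger inhibition. Compound 2 `FC(F)(F)c1ccccc1-c1nc(NCC#Cc2cccnc2)c2ccccc2n1` gives 8900 nM in this assay, and compound 3 `FC(F)(F)c1ccccc1-c1nc(NCc2ccc(-c3ccc(Cl)cc3)cc2)c2ccccc2n1` gives 3600 nM in this assay. Compound 3 stands at the smaller end of the three numbers: its separation from compound 2 lies beyond the scatter, whereas the step of a 1.6-fold lower number from compound 1 to compound 3 (0.20 log units; within the scatter) stays within it, so compound 3 and compound 1 cannot be told apart on these numbers. The step of a 1.6-fold higher number from compound 1 to compound 2 (0.19 log units; within the scatter) is likewise within the scatter.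

Compound 4 `FC(F)(F)c1ccccc1-c1nc(NCc2ccc(-c3cncnc3)cc2)c2ccccc2n1` differs from compound 3 in one place: pyrimidin-5-yl in place of 4-chlorophenyl on an aromatic carbon. Within the data shown here, the only measured step touching this position is a 1.6-fold lower number from compound 1 to compound 3 (0.20 log units; within the scatter), which exchanged the cyano group for the 4-chlorophenyl and moved the number by less than the scatter. Nothing measured here speaks to a pyrimidin-5-yl group at this position. The expectation is therefore a small shift, if any, toward a somewhat higher number, with a 1.4-fold higher number from compound 3 to compound 4 (0.14 log units; within the scatter) as the estimated step. Compound 4 is estimated at 5000 nM in this assay, expected to fall between 2000 nM and 13000 nM.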

Compound 4, half-maximal inhibitory concentration: 3000 nM
Compound 4: the middle estimate sits 1.7-fold (0.22 log units) above what was measured, within the range that was stated.
By their numbers in this assay, from the lowest: compounds 4, 3, 1 and 2 (each within the scatter of the next, the first and the last beyond it).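

In this assay, the step of a 1.2-fold lower number from compound 3 to compound 4 (0.08 log units; within the scatter) shows that this aromatic carbon, para to a large group, accepts a ring with 2 hetero atoms and 2 hydrogen-bond acceptors in place of a ring of carbon only, with no difference that these numbers can resolve. Until now the only change read at this place had been the exchange of cyano for 4-chlorophenyl, and the step of a 1.9-fold lower number from compound 1 to compound 4 (0.28 log units; within the scatter) now sets pyrimidin-5-yl against cyano with the same outcome, so cyano, 4-chlorophenyl and pyrimidin-5-yl cannot be told apart here, and the series has so far shown no group at this place that separates from the others. No independent measurement bears on what lies behind this result.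

The compounds shown leave open whether a saturated amine such as morpholine or a carboxylic acid on this aromatic carbon would carry the number beyond the scatter. They also leave open what replacing the trifluoromethyl group of the shared core with a methoxy group or a chlorine atom would do, since every compound here keeps that group unchanged.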